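The compounds below may be only part of what the source reports. "The series", "measured", "known", "first", "only" and "open" are said of these compounds alone.

Compound 1 `O=C(/C(=C\c1c(O)cc(O)cc1O)S(=O)(=O)c1ccccc1Br)c1ccc(Br)cc1` is the point of departure. In a functional assay on DU-145 cells (Homo sapiens) for inhibition, read by trypan blue exclusion, with a stated time of 96 h (a higher number here means a weaker inhibitor of growth, a lower number a stronger inhibitor of growth), compound 1 gives 50000 nM. Compound 2 `O=C(/C(=C\c1ccc(O)cc1O)S(=O)(=O)c1ccccc1Br)c1ccc(Br)cc1` carries one alteration of compound 1, namely (hydrogen in place of hydroxy on an aromatic carbon). For compound 2 this assay reports only a limit, > 100000 nM. The change therefore produced an at least 2.0-fold higher number from compound 1 to compound 2 (0.30 log units; that floor lies within the scatter), and as the value of compound 2 sits at the limit of > 100000 nM in this assay, at which 1 of the 3 values shown sits, the true size of that step is not known. Compound 3 `COc1ccc(/C=C(/SCc2ccc(Cl)cc2)C(=O)c2ccc(Br)cc2)cc1O` is built on a different core; how its core differs from that of compound 1 is not broken down here. In this assay compound 3 gives 1000 nM. Compound 4 `COc1ccc(/C=C(/SCc2ccc(Cl)cc2)C(=O)c2ccc(Br)cc2)cc1` has not yet been measured and differs from compound 3 by hydrogen in place of hydroxy on an aromatic carbon. This is the same kind of change as that from compound 1 to compound 2, but the surroundings differ: there the hydroxy was ortho to a large group and meta to two hydroxy groups, here it is ortho to a methoxy group and meta to a large group. He expects a weakening step, a 3.0-fold higher number from compound 3 to compound 4 (0.48 log units; beyond the scatter), smaller than the earlier one may have been. For compound 4 he estimates 3000 nM, between 800 nM and 12000 nM.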

Compound 4, concentration for 50% growth inhibition: 10000 nM
The estimate for compound 4 lay 3.3-fold (0.52 log units) below the measured number, and the stated range covers the measured number.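

In this assay, going from 3-hydroxy-4-methoxyphenyl to 4-methoxyphenyl gave a 10-fold higher number from compound 3 to compound 4 (1.00 log units; beyond the scatter), so on the core of compound 3 the hydroxy counts for a step beyond the scatter. Set beside the earlier step, this shows one fully readable size for the change, but not whether that size carries over from one core to the other: the same change on two cores in this assay, an at least 2.0-fold higher number (0.30 log units; that floor lies within the scatter) from compound 1 to compound 2 and a 10-fold higher number (1.00 log units; beyond the scatter) from compound 3 to compound 4; the limit leaves it open whether they differ

The value of compound 2 is a limit and not a number: the limit of > 100000 nM in this assay, at which 1 of the 4 values shown sits.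

The compounds shown leave open what would happen at that place on the ring with a group other than hydrogen, such as an amine or a carboxylic acid, and whether a longer chain in place of the methoxy group would alter the step. They also leave open whether the same change on a third core would give a step of similar size.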